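Lactam for thiazolidinedione on the benzylidene head

This account rests on a few compounds, and the source may have more. Where it says the series, first, only, none or still open, it means among the compounds named here.

Measured compounds, read in a functional assay on cells for agonist activity at Glucose-dependent insulinotropic receptor (Homo sapiens), read by a luciferase reporter, with a stated time of 6 h; on this read-out higher numbers stand for an effect only at larger amounts of compound and lower numbers for an effect already at smaller amounts:
compound 1 `CCc1cnc(N2CCC(c3nc(COc4ccc(/C=C5\SC(=O)NC5=O)cc4F)cs3)CC2)nc1`: 780 nM
compound 2 `CCOC(=O)CCc1cnc(N2CCC(c3nc(COc4ccc(-n5cnnn5)cc4)cs3)CC2)nc1`: "not determined" (no result reported)
compound 3 `NCCNC(=O)CCc1cnc(N2CCC(c3nc(COc4ccc(-n5cnnn5)cc4)cs3)CC2)nc1`: "not determined" (no result reported)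

Among the measured compounds shown here, compound 1 is the only member of the set with a number in this assay; compounds 2 and 3 carry no reported result, so compound 1 stands as the sole reference point and nothing can be said about its rank relative to the other two.

Compound 4 `CCc1cnc(N2CCC(c3nc(COc4ccc(/C=C5\CCNC5=O)cc4F)cs3)CC2)nc1` keeps the shared core of compound 1 and changes only the head on the benzylidene-bearing aromatic ring: a group of 7 heavy atoms (5 carbon, 1 nitrogen, 1 oxygen; one five-membered non-aromatic ring with 1 hetero atom) in place of a group of 8 heavy atoms (4 carbon, 1 nitrogen, 2 oxygen, 1 sulfur; one five-membered non-aromatic ring with 2 hetero atoms), on an aromatic carbon. In words, a group of 7 heavy atoms (5 carbon, 1 nitrogen, 1 oxygen; one five-membered non-aromatic ring with 1 hetero atom) takes the place of a group of 8 heavy atoms (4 carbon, 1 nitrogen, 2 oxygen, 1 sulfur; one five-membered non-aromatic ring with 2 hetero atoms), on an aromatic carbon, meta to a fluoro group and para to a large group.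

For the measured compounds named here, no step between measured compounds is available to calibrate this change; the expectation rests on compound 1 alone. Compound 4 is expected to be weaker than compound 1 by a step beyond the usual scatter, with the step from compound 1 to compound 4 estimated at a 6.4-fold higher number from compound 1 to compound 4 (0.81 log units; beyond the scatter). For compound 4 the estimate in this assay is 5000 nM, within a range from 1500 nM to 20000 nM.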

Compound 4, half-maximal effective concentration: 100 nM
Compound 4: middle estimate off by 50-fold (1.70 log units), on the high side; the measured number lies below the stated range.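

In this assay, the exchange on this aromatic carbon gives a 7.8-fold lower number from compound 1 to compound 4 (0.89 log units; beyond the scatter) and so sets the first measured direction for the head of the series. Activity at this position does not depend on the sulfur-containing head of compound 1: the group of 7 heavy atoms, with one five-membered non-aromatic ring with 1 hetero atom and 1 hydrogen-bond acceptor, outperforms the group of 8 heavy atoms with 3 hydrogen-bond acceptors, at least on this shared core and with the fluoro group in place. No measurement shown accounts for the gain, so the change can be recorded only as an empirical result.

Going by these compounds, whether a carboxylic acid or a longer chain on the same aromatic carbon would keep or extend this gain remains open, as does the contribution of the fluoro group to the value of compound 4. Compounds 2 and 3 carry no numbers, so steps involving them cannot be read.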